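The source may report more compounds than this note shows. Statements on the series, on what has been measured and on what is new or still open speak of the compounds shown alone.

The measured compounds in this set:

Compound 1, `O=c1ccn([C@@H]2O[C@H](COP(=O)(O)OP(=O)(O)OP(=O)(O)O)[C@@H](O)[C@H]2O)c(=S)[nH]1`, gives 1770 nM.
Compound 2, `O=c1ccn([C@@H]2O[C@H](COP(=O)(O)OP(=O)(O)O)[C@@H](O)[C@H]2O)c(=S)[nH]1`, gives only a limit of the assay, > 1000 nM, and not a number.
Compound 3, `O=c1[nH]c(=O)n([C@@H]2O[C@H](COP(=O)(O)OP(=O)(O)O)[C@@H](O)[C@H]2O)cc1Br`, gives 7200 nM.

In an in vitro functional assay on 1321-N1 cells for agonist activity at P2Y purinoceptor 4 (Homo sapiens) (on this read-out higher numbers stand for an effect only at larger amounts of compound and lower numbers for an effect already at smaller amounts), compound 1 gives 1770 nM. Compound 2 differs from compound 1 by a hydrogen atom in place of a group of 4 heavy atoms (3 oxygen, 1 phosphorus; no ring), on an oxygen. The resulting step that the limit leaves unreadable from compound 1 to compound 2 has no readable size because of the limit of > 1000 nM in this assay, at which 1 of the 3 values shown sits. Compound 3 carries a different core; how the two cores differ is not broken down here. In this assay compound 3 gives 7200 nM, the highest of the two numbers, and its separation from compound 1 lies beyond the usual scatter.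

Compound 4, `O=c1[nH]c(=O)n([C@@H]2O[C@H](COP(=O)(O)O)[C@@H](O)[C@H]2O)cc1Br`, has not yet been measured. It differs from compound 3 by a hydrogen atom in place of a group of 4 heavy atoms (3 oxygen, 1 phosphorus; no ring), on an oxygen, and the surroundings of that place are word for word the same as for the change from compound 1 to compound 2, so it is the same change made on the other core. The earlier instance of this change yields no size, so the expectation for compound 4 rests on compound 3 already sitting at 7200 nM. It also rests on compound 2 reaching only a limit of the assay after the same change. Compound 4 is therefore expected to give about 30000 nM, somewhere between 8000 nM and 120000 nM. The step this estimate implies is a 4.2-fold higher number from compound 3 to compound 4 (0.62 log units; beyond the scatter), and a limit rather than a number is considered quite likely.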

Compound 4, half-maximal effective concentration: > 100000 nM
Compound 4: only a limit was reported; the forecaster's own chance of this, stated with the estimate: 60%; at least 3.3-fold (0.52 log units) between middle value and limit.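

In this assay compound 4 gives only a limit of the assay, > 100000 nM, and not a number. On the core of compound 3, putting a hydrogen atom in place of the group of 4 heavy atoms, on an oxygen whose other neighbours are phosphorus, gives a large change that lies beyond the usual scatter: an at least 13-fold higher number from compound 3 to compound 4 (1.14 log units; beyond the scatter). The same change on the core of compound 1 has no readable size, so the series gives a size on one core only and does not show whether that size carries over from one core to the other, because compound 2 stands at a limit: the limit of > 1000 nM in this assay, at which 1 of the 4 values shown sits.

The compounds shown leave open how this change behaves on any core other than these two, since one readable instance cannot establish a pattern. They also leave open what a group other than hydrogen would do at this oxygen, for example a methyl group, an amine or a longer chain of phosphorus and oxygen atoms, and whether any such group would give a number rather than a limit.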